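Phenyl for methyl on the pyrazole nitrogen, second core

A few compounds are considered here, and "the series" means these few. Any claim that something is new, unique, unknown or untested is made for them only; others in the source may bear on it.

Measured compounds:
compound 1, `Cn1cc(NC(=O)c2cccc(NS(=O)(=O)c3ccccc3)c2)cn1`, 78500 nM
compound 2, `O=C(Nc1cnn(-c2ccccc2)c1)c1cccc(NS(=O)(=O)c2ccccc2)c1`, 15300 nM
compound 3, `Cn1cc(NC(=O)c2ccc(NS(=O)(=O)c3ccccc3)cc2)cn1`, 92800 nM

All three were run in a functional assay on HeLa cells (Homo sapiens) for inhibition, read by MTT assay, with a stated time of 48 h; a higher number here means a weaker inhibitor, a lower number a stronger inhibitor. Compound 1 gives 78500 nM in this assay, compound 2 gives 15300 nM, and compound 3 gives 92800 nM. Compound 3 and compound 1 lie within the scatter of each other; compound 2 stands apart from both, beyond the scatter.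

Compound 1 and compound 2 share a core and differ in one place only, (phenyl in place of methyl on an aromatic nitrogen). This change gave a 5.1-fold lower number from compound 1 to compound 2 (0.71 log units; beyond the scatter).

Compound 3 carries the same atoms as compound 1, joined differently; the difference between the two cores is not broken down here. Compound 4, `O=C(Nc1cnn(-c2ccccc2)c1)c1ccc(NS(=O)(=O)c2ccccc2)cc1`, is not yet measured. It differs from compound 3 by phenyl in place of methyl on an aromatic nitrogen. For the measured compounds named here, the place lines of the two changes are identical word for word, so this is the same change as the one from compound 1 to compound 2, made on the core of compound 3.

Going by the values given here, with only one earlier instance of this change to rest on, the expectation for compound 4 is a step of about the same size: a 5.2-fold lower number from compound 3 to compound 4 (0.71 log units; beyond the scatter) is expected in this assay, because the same change gave a 5.1-fold lower number from compound 1 to compound 2 (0.71 log units; beyond the scatter). On that basis compound 4 is estimated at 18000 nM in this assay, with a range from 8000 nM to 45000 nM. From the compounds shown here alone, whether the second core carries the change in the same way is unknown until the number is in.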

Compound 4, half-maximal inhibitory concentration: 37100 nM
Beside the measured number, compound 4's estimate is 2.1-fold (0.31 log units) below it; the range from low to high includes it.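

In this assay phenyl in place of methyl on an aromatic nitrogen gives a 2.5-fold lower number from compound 3 to compound 4 (0.40 log units; beyond the scatter) on the second core, so the number falls in the same direction on both cores shown. This rests on two pairs only: it shows that the direction and rough size of the step held on these two cores, but it does not show that the change would carry to a further core, and it says nothing about why the number moves or what lies behind the cell read-out. Within this small set the two steps cannot be told apart as different in size: the same change on two cores in this assay, a 5.1-fold lower number (0.71 log units; beyond the scatter) from compound 1 to compound 2 and a 2.5-fold lower number (0.40 log units; beyond the scatter) from compound 3 to compound 4, 2.1-fold (0.31 log units) apart, within the scatter of two such steps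

The compounds shown leave open how other groups on that aromatic nitrogen would behave, such as an ethyl, a benzyl or a longer chain, and whether the entering phenyl would keep the step if it carried a fluorine or a methoxy group. Also open, from the compounds shown here alone, is whether the same step would appear with a carboxylic acid or an amine added elsewhere on the shared core, and whether it would hold in a cell line other than the one used here.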